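Trifluoromethyl for Chloro on the Weaker Methoxy Core

A few compounds are considered here, and "the series" means these few. Any claim that something is new, unique, unknown or untested is made for them only; others in the source may bear on it.

Three compounds have been measured in a functional assay on MIA PaCa-2 cells (Homo sapiens) for antiproliferative activity, read by sulforhodamine B assay, with a stated time of 48 h; on this read-out lower numbers stand for stronger inhibition of growth and higher numbers for weaker inhibition of growth:

compound 1, `O=C(NCc1cn(Cc2ccc(Cl)cc2)nn1)c1cn(-c2ccccc2)nc1-c1ccc(Cl)cc1`, 410 nM
compound 2, `O=C(NCc1cn(Cc2ccc(C(F)(F)F)cc2)nn1)c1cn(-c2ccccc2)nc1-c1ccc(Cl)cc1`, 1100 nM
compound 3, `COc1ccc(-c2nn(-c3ccccc3)cc2C(=O)NCc2cn(Cc3ccc(Cl)cc3)nn2)cc1`, 26300 nM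

Compound 4, `COc1ccc(-c2nn(-c3ccccc3)cc2C(=O)NCc2cn(Cc3ccc(C(F)(F)F)cc3)nn2)cc1`, is not yet measured. Compound 3 differs from compound 1 by methoxy in place of chloro on an aromatic carbon, and in this assay that change gave a 64-fold higher number from compound 1 to compound 3 (1.81 log units; beyond the scatter). The change from compound 3 to compound 4 is trifluoromethyl in place of chloro on an aromatic carbon. The same kind of change, (trifluoromethyl in place of chloro on an aromatic carbon), at a place described in the same words, gave a 2.7-fold higher number from compound 1 to compound 2 (0.43 log units; beyond the scatter). Among the measured compounds shown here, a step of similar size is expected from compound 3 to compound 4, namely a 2.5-fold higher number from compound 3 to compound 4 (0.39 log units; beyond the scatter), because it rests on a 2.7-fold higher number from compound 1 to compound 2 (0.43 log units; beyond the scatter) alone; no other pair bears on it. Compound 4 is therefore estimated at 65000 nM, between 25000 nM and 160000 nM, with a fair chance that the assay reports only a limit.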

Compound 4, concentration for 50% growth inhibition: > 100000 nM
Compound 4: only a limit was reported (the forecaster's own chance of this, stated with the estimate: 40%); at least 1.5-fold (0.18 log units) between middle value and limit.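

In this assay compound 4 gives > 100000 nM, which is a limit of the assay. Trifluoromethyl in place of chloro went the same way on the methoxy-bearing core, with an at least 3.8-fold higher number from compound 3 to compound 4 (0.58 log units; beyond the scatter), but its size there stays unfixed: the same change on two cores in this assay, a 2.7-fold higher number (0.43 log units; beyond the scatter) from compound 1 to compound 2 and an at least 3.8-fold higher number (0.58 log units; beyond the scatter) from compound 3 to compound 4; the limit leaves it open whether they differ. Methoxy in place of chloro also went the same way with a 4-(trifluoromethyl)benzyl group present, with an at least 90-fold higher number from compound 2 to compound 4 (1.95 log units; beyond the scatter), and again only a minimum is known: the same change on two cores in this assay, a 64-fold higher number (1.81 log units; beyond the scatter) from compound 1 to compound 3 and an at least 90-fold higher number (1.95 log units; beyond the scatter) from compound 2 to compound 4; the limit leaves it open whether they differ.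

These two pairs cannot show how far either change carries beyond the four compounds. The compounds shown leave open how an amine, a nitrile or a carboxylic acid in place of chloro on the benzyl group would read in this assay, and whether any group there gives a lower number than chloro.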